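Swapping butyl for tert-butyl in a narrow series

This account rests on a few compounds, and the source may have more. Where it says the series, first, only, none or still open, it means among the compounds named here.

In a functional assay on HT-29 cells (Homo sapiens) for antiproliferative activity, read by sulforhodamine B assay, with a stated time of 72 h (a lower number here means a stronger inhibitor, a higher number a weaker inhibitor), compound 1 (`CCCCCCCOc1ccc(CCC(CO)(CO)NC(C)=O)c2ccccc12`) gives 17600 nM and compound 2 (`CCCCCCCOc1ccc(CCC(CO)(CO)NC(=O)CCCCCCC)c2ccccc12`) gives 18800 nM while compound 3 (`CCCCCCCOc1ccc(CCC(CO)(CO)NC(=O)OCCCC)c2ccccc12`) gives 22400 nM and so stands within the scatter of both. Compound 4 (`CCCCCCCOc1ccc(CCC(CO)(CO)NC(=O)OC(C)(C)C)c2ccccc12`) has the same atoms as compound 3, joined differently, with tert-butyl in place of butyl on an oxygen next to a carbonyl group. The measured changes closest to this one are hexyl in place of hydrogen (a 1.1-fold higher number from compound 1 to compound 2 (0.03 log units; within the scatter)), butoxy in place of methyl (a 1.3-fold higher number from compound 1 to compound 3 (0.10 log units; within the scatter)) and butoxy in place of heptyl (a 1.2-fold higher number from compound 2 to compound 3 (0.08 log units; within the scatter)), and all three stay within the scatter. For the measured compounds named here, no measured pair changes butyl to tert-butyl itself, so this evidence is indirect. On that basis the step expected in this assay (a 1.1-fold lower number from compound 3 to compound 4 (0.05 log units; within the scatter)) is none beyond the scatter, in either direction. For compound 4 the estimated value is 20000 nM (11000 nM to 36000 nM as the expected range).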

Compound 4, half-maximal inhibitory concentration: 21400 nM
Compound 4: the middle estimate sits 1.1-fold (0.03 log units) below what was measured, and the stated range covers the measured number.
By their numbers in this assay, from the lowest: compounds 1, 2, 4 and 3 (each within the scatter of the next).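

Tert-butyl in place of butyl on an oxygen next to a carbonyl group adds something the earlier compounds could not show: with the same atoms joined differently, the group's shape can change and this assay still does not separate the pair, a 1.0-fold lower number from compound 3 to compound 4 (0.02 log units; within the scatter). Tert-butoxy on the carbonyl carbon is likewise not separated from heptyl, a 1.1-fold higher number from compound 2 to compound 4 (0.06 log units; within the scatter), or from methyl, a 1.2-fold higher number from compound 1 to compound 4 (0.08 log units; within the scatter), so all the groups shown at this place remain within the scatter of one another. Nothing available here offers an explanation for this lack of separation.

On these data alone, it remains open whether any group on this carbonyl carbon can move the number beyond the scatter. A carboxylic acid or an amine at the end of the chain would test this, as would a phenyl ring in place of the tert-butyl.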